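Aminothiazole in place of imidazole on the bromoindazole series

The source may report more compounds than this note shows. Statements on the series, on what has been measured and on what is new or still open speak of the compounds shown alone.

Three compounds share the core of compound 1 `FC(F)(F)c1cccc(CNc2cc(Br)cc3[nH]ncc23)c1` and have been measured in an assay for inhibition of Tryptophan 2,3-dioxygenase (Homo sapiens), with a stated time of 1 h, tested at 10 uM; a lower number here means less inhibition, a higher number more inhibition at the concentration tested (going by the name of the read-out). Compound 1 gives 56%. Compound 2 `Oc1ccc(CNc2cc(Br)cc3[nH]ncc23)cc1Cl` gives 19%. Compound 3 `Brc1cc(NCc2cnc[nH]2)c2cn[nH]c2c1` gives 54%, which places it in the upper part of the three numbers: the value of compound 1 sits within the usual scatter of it, while the value of compound 2 lies well beyond the scatter below it. Going by the values given here, no single-point step between measured compounds is available, so the outcome of the change at the chain carbon has no measured precedent here.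

Compound 4 `Nc1nc(CNc2cc(Br)cc3[nH]ncc23)cs1` is not yet measured. It differs from compound 3 as follows: 2-amino-1,3-thiazol-4-yl in place of 1H-imidazol-5-yl on a saturated chain carbon bound to a nitrogen on an aromatic ring. Given that the two five-membered heteroaromatic groups are of similar size, the expected step of a number 9 percentage points lower from compound 3 to compound 4 (within the scatter) is small, with no strong direction and a real chance that it stays within the scatter. The expected value for compound 4 in this assay is therefore 45%, with a range from 20% to 70%.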

Compound 4, a percentage reported as inhibition, at one concentration (the size of the read-out at that concentration, not a potency): 73%
The estimate for compound 4 lay 28 percentage points below the measured number; measured number above the stated range.
By their numbers in this assay, from the lowest: compound 2; then compounds 3 and 1 (each within the scatter of the next); then compound 4.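

At the saturated chain carbon bound to a nitrogen on an aromatic ring, 2-amino-1,3-thiazol-4-yl in place of 1H-imidazol-5-yl gives a number 19 percentage points higher from compound 3 to compound 4 (beyond the scatter) in this assay. Going by these compounds alone, this is the first single-change step, and it shows that the read-out at this position depends on which five-membered aromatic ring is attached, even though the two rings are close in size. No measurement shown bears on which feature of the entering group lies behind the step.

Still open, going by these compounds, is whether the amine on the thiazole ring matters, which a plain 1,3-thiazol-4-yl group would separate from the effect of the ring itself. Also open, on these data alone, is whether the step holds with a longer chain between the ring and the nitrogen, and whether it would appear as a difference in potency rather than in a read-out at one concentration.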